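Hydrogen in place of methoxy on the aryl ring

The source may hold more compounds than are shown below. What is called first, only, known or untested is meant among the compounds shown, and "the series" means these compounds.

Measured so far:
compound 1 `COc1cc(C2Oc3c(OC)cc(/C=C/C=O)cc3C2COC(=O)c2ccc(O)cc2)ccc1O`, > 200000 nM
compound 2 `COc1cc([C@H]2Oc3c(OC)cc(/C=C/COC(=O)c4ccc(O)cc4)cc3[C@@H]2COC(=O)c2ccc(O)cc2)cc(OC)c1O`, > 200000 nM

In a functional assay, read by chemiluminescence (on this read-out lower numbers stand for stronger inhibition and higher numbers for weaker inhibition), compound 1 reaches only a limit of the assay, > 200000 nM. Compound 2 likewise reaches only a limit in this assay, > 200000 nM. Both values sit at the limit of > 200000 nM in this assay, at which 2 of the 2 values shown sit, so compound 2 stands nowhere on a scale of numbers, only at the limit.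

Compound 3 `COc1cc([C@H]2Oc3c(OC)cc(/C=C/COC(=O)c4ccc(O)cc4)cc3[C@@H]2COC(=O)c2ccc(O)cc2)ccc1O` differs from compound 2 by hydrogen in place of methoxy on an aromatic carbon. For the measured compounds named here, no measured step exists for this change, so the expected step of a number no higher from compound 2 to compound 3 (the limit leaves the size open) is none beyond the scatter. For compound 3 the estimate in this assay is 200000 nM, expected between 100000 nM and 400000 nM.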

Compound 3, half-maximal inhibitory concentration: > 200000 nM
Compound 3: no number, only a limit; the forecaster's own chance of this, stated with the estimate: 85%; the middle value sits exactly at the limit.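

No step can be read between compound 2 and compound 3, as each gives only a limit, not a number: the limit of > 200000 nM in this assay, at which 3 of the 3 values shown sit.

The compounds shown leave open whether hydrogen in place of methoxy changes inhibition, and how strong any inhibition by these compounds is.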